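Replacing 2,5-dimethylphenyl with 3-chlorophenyl on a sulfonamide nitrogen

A few compounds are considered here, and "the series" means these few. Any claim that something is new, unique, unknown or untested is made for them only; others in the source may bear on it.

Three compounds have numbers in a functional assay on HT-29 cells (Homo sapiens) for antiproliferative activity, read by sulforhodamine B assay, with a stated time of 48 h; on this read-out higher numbers stand for weaker inhibition and lower numbers for stronger inhibition:

Compound 1 `O=C1NCCN1c1ccc(S(=O)(=O)Nc2ccc(F)c(F)c2)cc1`: 350 nM
Compound 2 `O=C1NCCN1c1ccc(S(=O)(=O)Nc2cccc(Br)c2)cc1`: 77 nM
Compound 3 `Cc1ccc(C)c(NS(=O)(=O)c2ccc(N3CCNC3=O)cc2)c1`: 46 nM

The three share a core and differ only in the group on the sulfonamide nitrogen. Compound 3 stands at the low end of the numbers in this assay with one close neighbour: a 1.7-fold lower number from compound 2 to compound 3 (0.22 log units; within the scatter). Two further steps go beyond the scatter: a 4.5-fold lower number from compound 1 to compound 2 (0.66 log units; beyond the scatter) and a 7.6-fold lower number from compound 1 to compound 3 (0.88 log units; beyond the scatter).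

Compound 4 `O=C1NCCN1c1ccc(S(=O)(=O)Nc2cccc(Cl)c2)cc1` has not yet been measured. Its change is 3-chlorophenyl in place of 2,5-dimethylphenyl on a sulfonamide nitrogen. Among the measured compounds shown here, no measured step makes this exact exchange. The best guide is compound 2 at 77 nM. Its 3-bromophenyl group is the measured group closest to 3-chlorophenyl. Compound 1 at 350 nM also carries a halogen-bearing group, which keeps the upper end of the expectation open. A small rise is therefore expected, not clearly beyond the scatter. The expected change is a 1.8-fold higher number from compound 3 to compound 4 (0.27 log units; within the scatter). Compound 4 is estimated at 85 nM, with an expected range from 35 nM to 220 nM.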

Compound 4, half-maximal inhibitory concentration: 55 nM
The estimate for compound 4 lay 1.5-fold (0.19 log units) above the measured number; the measured number falls inside the stated range.
By their numbers in this assay, from the lowest: compounds 3, 4 and 2 (each within the scatter of the next); then compound 1.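

Exchanging 2,5-dimethylphenyl for 3-chlorophenyl on the sulfonamide nitrogen gives a 1.2-fold higher number from compound 3 to compound 4 (0.08 log units; within the scatter) in this assay, so two groups with different substituents, one carrying only carbon and the other chlorine, cannot be told apart at this position. Among the compounds shown here, the direct exchange of chloro for bromo on an aromatic carbon gives a 1.4-fold lower number from compound 2 to compound 4 (0.15 log units; within the scatter), which adds a matched halogen pair that the earlier compounds lacked and likewise leaves the two groups within the scatter of each other. The 3-chlorophenyl group also separates clearly from the 3,4-difluorophenyl group, with a 6.4-fold lower number from compound 1 to compound 4 (0.80 log units; beyond the scatter), so the presence of halogen alone does not place a compound at the low end of these numbers: compound 1 goes against any such reading, while compounds 2, 3 and 4 form one group within the scatter.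

No accompanying measurement bears on why these groups give the numbers they do. The compounds shown leave open whether an amine, a carboxylic acid or a methoxy group on this phenyl ring, or a longer chain on the sulfonamide nitrogen in place of the ring, would stay with compounds 2, 3 and 4 or move toward compound 1.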